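From compound 2 to compound 3: a smaller substituent

The compounds below may be only part of what the source reports. "The series", "measured", "known", "first", "only" and "open" are said of these compounds alone.

In an in vitro assay on Sf21 cells for inhibition of high affinity 3',5'-cyclic-AMP phosphodiesterase 7A (Homo sapiens) (on this read-out higher numbers stand for weaker inhibition and lower numbers for stronger inhibition), compound 1 `CNc1nc(NC2CCCC2)nc(NC2(C#N)CCCCC2)n1` gives > 5000 nM, which is a limit of the assay and not a number. Compound 2 `CNc1nc(NC2(C#N)CCCCC2)nc(-n2cnc(C)n2)n1` likewise gives > 5000 nM in this assay, again a limit rather than a number. The step that the two limits leave unreadable from compound 1 to compound 2 therefore cannot be read in size, as both values sit at the limit of > 5000 nM in this assay, at which 2 of the 2 values shown sit. Going by the values given here, compound 2 thus stands at the limit of this assay, and the only other value shown is a limit as well.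

Compound 3 `CNc1nc(C#N)nc(NC2(C#N)CCCCC2)n1` differs from compound 2 by cyano in place of 3-methyl-1H-1,2,4-triazol-1-yl on an aromatic carbon. Among the compounds with values here, no measured step bears on this change: the single step between measured compounds concerns a different group at a different place and is itself unreadable. With both measured values at the limit there is no direction in which to extrapolate. Compound 3 is expected to stay near the limit, so the step that the limit leaves unreadable from compound 2 to compound 3 is expected to be small. Compound 3 is therefore estimated at 8000 nM, with a range from 2000 nM to 30000 nM, and it is expected that the assay will most likely again report only a limit.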

Compound 3, half-maximal inhibitory concentration: > 1000 nM
Compound 3 gave a limit, no number; the forecaster's own chance of this, stated with the estimate: 70%; the middle value lies beyond the limit too.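

In this assay compound 3 gives > 1000 nM, which is a limit of the assay and not a number. None of the steps among compound 1, compound 2 and compound 3 can be read in size. The compounds shown leave open what any of the three would give as an actual number in this assay, and whether the group changed on the aromatic carbon affects it.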